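The compounds below may be only part of what the source reports. "The series", "measured", "known", "first", "only" and "open" are said of these compounds alone.

Measured so far in a functional assay on HL-60 cells (Homo sapiens) for inhibition, read by MTT assay, with a stated time of 72 h, tested at 30 uM; a lower number here means less inhibition of growth, a higher number more inhibition of growth at the concentration tested:
compound 1 `C=CCc1ccc(OCc2cn(-c3cccc([N+](=O)[O-])c3)nn2)c(O)c1`: 29.8%
compound 2 `C=CCc1ccc(OCc2cn(-c3ccc(C#N)cc3)nn2)c(O)c1`: 20.8%

Compound 2 stands at 20.8%. That value lies within the usual scatter of compound 1 at 29.8%, so the two cannot be ranked. Among the compounds with values here, no measured pair here differs in only one place, so the numbers offer no measured size of change to draw on.

The next compound, compound 3 `C=CCc1ccc(OCc2cn(-c3ccccc3CO)nn2)c(O)c1`, carries 2-(hydroxymethyl)phenyl in place of 4-cyanophenyl on an aromatic nitrogen. Nothing measured yet shows how this swap acts in this assay. Taking compound 2 at 20.8% as the starting point, no change beyond the scatter is expected, in either direction. The estimated step is a number 2.2 percentage points higher from compound 2 to compound 3 (within the scatter). For compound 3 the expected value is 23%, with an estimated range of 9% to 38%.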

Compound 3, percent growth inhibition at one concentration: 31.7%
For compound 3 the middle estimate is 8.7 percentage points below the measured one; the range from low to high includes it.
By their numbers in this assay, from the lowest: compounds 2, 1 and 3 (each within the scatter of the next, the first and the last beyond it).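

In this assay, within the data shown here, this is the first measured step at the aromatic nitrogen of the five-membered ring: swapping 4-cyanophenyl for 2-(hydroxymethyl)phenyl gives a number 10.9 percentage points higher from compound 2 to compound 3 (beyond the scatter). So growth inhibition at the concentration tested can respond to the aryl group at this position, though the step is modest. As the two names show, the swap changes both the substituent and where it sits on the phenyl ring, and no measurement here explains the step.

From the compounds shown here alone, what remains open is whether the hydroxymethyl group itself, its place on the ring, or the loss of the nitrile accounts for this step. An unsubstituted phenyl, or an aminomethyl group or a carboxylic acid in place of the hydroxymethyl group, would show how far this position tolerates other groups.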